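The compounds below may be only part of what the source reports. "The series", "measured", "known", "first", "only" and "open" are said of these compounds alone.

Compound 1 `NS(=O)(=O)c1ccc(CNc2nc(Nc3cccc(NC(=O)N4CCCC4)c3)ncc2Br)cc1` gives 20000 nM
Compound 2 `NS(=O)(=O)c1ccc(CNc2ccnc(Nc3cccc(NC(=O)N4CCCC4)c3)n2)cc1` gives 169000 nM

In a physicochemical assay for solubility, in phosphate buffer, measured as kinetic solubility, with a stated time of 24 h, at pH 7.4 (on this read-out lower numbers stand for lower solubility and higher numbers for higher solubility), compound 2 gives 169000 nM as the higher of the two numbers. Compound 3 `O=C(NCCCNc1ccnc(Nc2cccc(NC(=O)N3CCCC3)c2)n1)C1CCC1` differs from it by one change (2-((cyclobutylcarbonyl)amino)ethyl in place of 4-sulfamoylphenyl on a saturated chain carbon bound to a nitrogen on an aromatic ring) on a saturated chain carbon bound to a nitrogen on an aromatic ring. Among the measured compounds shown here, the only measured step (an 8.5-fold higher number from compound 1 to compound 2 (0.93 log units; beyond the scatter)) is hydrogen in place of bromo on an aromatic carbon. That is a different change, so it gives no direct guide. With nothing closer to go on, no step beyond the scatter is expected in this assay (a 1.1-fold lower number from compound 2 to compound 3 (0.02 log units; within the scatter)) in either direction. For compound 3 the estimated value is 160000 nM within an expected range (60000 nM to 350000 nM).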

Compound 3, solubility: 136000 nM
The estimate for compound 3 lay 1.2-fold (0.07 log units) above the measured number; low and high end bracket the measured number.
By their numbers in this assay, from the lowest: compound 1; then compounds 3 and 2 (each within the scatter of the next).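

In this assay, replacing 4-sulfamoylphenyl with 2-((cyclobutylcarbonyl)amino)ethyl gives only a small step (a 1.2-fold lower number from compound 2 to compound 3 (0.09 log units; within the scatter)). So at this place, on a saturated chain carbon bound to a nitrogen on an aromatic ring, a six-membered aromatic ring can give way to a chain carrying a four-membered ring without a step beyond the scatter. Only this one chain is shown here, so it remains open whether an amine, a carboxylic acid or a longer chain would do the same. Nothing measured here offers an explanation for this result.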